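A few compounds are considered here, and "the series" means these few. Any claim that something is new, unique, unknown or untested is made for them only; others in the source may bear on it.

Measured so far in a toxicity assay on MCF-10A cells (Homo sapiens) for cytotoxicity, read by MTT assay, with a stated time of 48 h; on this read-out higher numbers stand for weaker inhibition and lower numbers for stronger inhibition:

Compound 1 `O=C(/C=C/c1ccc2c(c1)B(O)OC2)c1ccco1`: 7400 nM
Compound 2 `Cn1cccc1C(=O)/C=C/c1ccc2c(c1)B(O)OC2`: a limit of the assay, > 100000 nM
Compound 3 `Cc1ccc(C(=O)/C=C/c2ccc3c(c2)B(O)OC3)cc1C`: 4700 nM

Compound 1 holds the higher of the two numbers that were read in this assay; compound 3 sits within the scatter of it, and compound 2 gives only a limit. Compound 4 `O=C(/C=C/c1ccc2c(c1)B(O)OC2)c1ccccc1O` keeps the shared core of compound 1; the change is 2-hydroxyphenyl in place of furan-2-yl on a carbonyl carbon. Among the measured compounds shown here, only one measured step bears on this place: an at least 13-fold higher number from compound 1 to compound 2 (1.13 log units; beyond the scatter), where the value reached the assay limit (the limit of > 100000 nM in this assay, at which 1 of the 3 values shown sits). Compound 3, which carries a six-membered carbon ring on that carbonyl carbon, lies within the scatter of compound 1, so the expected step for compound 4 is a 1.1-fold higher number from compound 1 to compound 4 (0.03 log units; within the scatter). The estimate for compound 4 is therefore 8000 nM, ranging from 3000 nM to 30000 nM.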

Compound 4, half-maximal inhibitory concentration: 53700 nM
Compound 4: the middle estimate sits 6.7-fold (0.83 log units) below what was measured; measured number outside the range, above it.
By their numbers in this assay, from the lowest: compounds 3 and 1 (each within the scatter of the next); then compound 4. At a limit, above all of these: compound 2.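

In this assay, placing 2-hydroxyphenyl on the carbonyl carbon gives a 7.3-fold higher number from compound 1 to compound 4 (0.86 log units; beyond the scatter), so this position responds to more than the limit-bound change seen before. Compound 3 also carries a six-membered carbon ring there and gives 4700 nM, so such a ring alone does not set the number. The other step, an at least 1.8-fold lower number from compound 2 to compound 4 (0.27 log units; that floor lies within the scatter), rests on compound 2, whose value is a limit: the limit of > 100000 nM in this assay, at which 1 of the 4 values shown sits.

As far as these compounds go, whether the hydroxy group itself drives this rise stays open. A plain phenyl, or an amine or a carboxylic acid in place of that hydroxy group, could help to settle it.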